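The source may hold more compounds than are shown below. What is called first, only, known or untested is meant among the compounds shown, and "the series" means these compounds.

Two compounds share one core. Going by the values given here, in a functional assay on A549 cells (Homo sapiens) for cytotoxicity, read by sulforhodamine B assay, with a stated time of 72 h (on this read-out higher numbers stand for weaker inhibition and lower numbers for stronger inhibition), compound 1 `CCS(=O)(=O)Nc1cc(-c2ccc3ncnc(Nc4ccc(OC(F)(F)F)cc4)c3c2)cnc1OC` gives 25400 nM, and compound 2 `CCS(=O)(=O)Nc1cc(-c2ccc3ncnc(Nc4cccc(C(=O)OC)c4)c3c2)cnc1OC` gives 1100 nM, the lowest of the two numbers; the only step between them, a 23-fold lower number from compound 1 to compound 2 (1.36 log units; beyond the scatter), exchanges the whole phenyl group on the nitrogen. Compound 3 `CCS(=O)(=O)Nc1cc(-c2ccc3ncnc(Nc4ccc(F)c(C(=O)OC)c4)c3c2)cnc1OC` differs from compound 2 by fluoro in place of hydrogen on an aromatic carbon. Among the compounds with values here, no measured step concerns an added fluoro, so that step offers little guidance, and for compound 3 a change no larger than the scatter is expected, a 1.1-fold lower number from compound 2 to compound 3 (0.04 log units; within the scatter). Compound 3 is therefore estimated at 1000 nM, between 350 nM and 3000 nM.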

Compound 3, half-maximal inhibitory concentration: 3420 nM
Compound 3: the middle estimate sits 3.4-fold (0.53 log units) below what was measured; the whole stated range lies below it.
By their numbers in this assay, from the lowest: compound 2; then compound 3; then compound 1.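

In this assay, fluoro in place of hydrogen, ortho to a methoxycarbonyl group, does not pass unnoticed: the step gives a 3.1-fold higher number from compound 2 to compound 3 (0.49 log units; beyond the scatter) and so shows that this ring position responds to a single added atom. The 4-fluoro-3-(methoxycarbonyl)phenyl group still keeps part of the advantage over 4-(trifluoromethoxy)phenyl, with a 7.4-fold lower number from compound 1 to compound 3 (0.87 log units; beyond the scatter) as the step. No measurement shown here accounts for the shift.

Open, as far as these compounds go, is whether chloro or methyl at this position would move the number the same way. Also open, from the compounds shown here alone, is how a carboxylic acid in place of the methoxycarbonyl group would read.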